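This account rests on a few compounds, and the source may have more. Where it says the series, first, only, none or still open, it means among the compounds named here.

Series notes. Compound 1 `CCNCc1cc(-c2c(C(=O)NCC)noc2-c2cc(C(C)C)c(O)cc2O)on1` gives 45 nM in a functional assay on A2780 cells (Homo sapiens) for inhibition; a lower number here means a stronger inhibitor, a higher number a weaker inhibitor. Compound 2 `CCNC(=O)c1noc(-c2cc(C(C)C)c(O)cc2O)c1-c1cc(CNC(C)C)no1` gives 38 nM in this assay; the change methyl in place of hydrogen on a saturated chain carbon bound to an amine nitrogen and a saturated chain carbon made a 1.2-fold lower number from compound 1 to compound 2 (0.07 log units; within the scatter). Compound 3 `CCNC(=O)c1noc(-c2cc(C(C)C)c(O)cc2O)c1-c1cnn(C)c1` gives 20 nM in this assay; its core differs from the core of compound 1 by 1-methyl-1H-pyrazol-4-yl in place of 3-((ethylamino)methyl)-1,2-oxazol-5-yl on an aromatic carbon. Compound 4 `CCNC(=O)c1noc(-c2cc(C(C)C)c(O)cc2O)c1-c1cnn(CC)c1` is not yet measured; it differs from compound 3 by methyl in place of hydrogen on a saturated chain carbon bound to an aromatic nitrogen, the same kind of change as that made from compound 1 to compound 2, though here the carbon is bound to an aromatic nitrogen rather than to an amine nitrogen and a saturated chain carbon. Because the earlier instance gave a 1.2-fold lower number from compound 1 to compound 2 (0.07 log units; within the scatter), only a small step is expected here, a 1.1-fold lower number from compound 3 to compound 4 (0.05 log units; within the scatter). Compound 4 is accordingly estimated at 18 nM in this assay, with a likely span from 8 nM to 40 nM.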

Compound 4, half-maximal inhibitory concentration: 30 nM
Compound 4: middle estimate off by 1.7-fold (0.22 log units), on the low side; low and high end bracket the measured number.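

In this assay, methyl in place of hydrogen on a saturated chain carbon bound to an aromatic nitrogen gives a 1.5-fold higher number from compound 3 to compound 4 (0.18 log units; within the scatter), and the two swaps of the side group give a 1.3-fold lower number from compound 2 to compound 4 (0.10 log units; within the scatter) and a 1.5-fold lower number from compound 1 to compound 4 (0.18 log units; within the scatter), so none of these steps separates the compounds. Set beside the earlier instance, the change shows no detectable dependence on the core: the same change on two cores in this assay, a 1.2-fold lower number (0.07 log units; within the scatter) from compound 1 to compound 2 and a 1.5-fold higher number (0.18 log units; within the scatter) from compound 3 to compound 4, 1.8-fold (0.25 log units) apart, within the scatter of two such steps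
This rests on only two instances, with the carbon bound to different neighbours, and it establishes neither a shared direction nor a rule for other cores.

Still open, from the compounds shown here alone, is how a longer chain, such as propyl, or an amine-bearing chain in place of the ethyl of 1-ethyl-1H-pyrazol-4-yl would read in this assay.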